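This account rests on a few compounds, and the source may have more. Where it says the series, first, only, none or still open, it means among the compounds named here.

- Compound 1 `CCOC(=O)CC1C(C(=O)OCC)=C(N)Oc2ccc(-c3cc(OC)cc(OC)c3)cc21`: 10700 nM
- Compound 2 `CCOC(=O)CC1C(C(=O)OCC)=C(N)Oc2ccc(-c3cccs3)cc21`: > 80000 nM

In a functional assay on HL-60 cells (Homo sapiens) for cytotoxicity, read by CellTiter-Blue, with a stated time of 48 h (on this read-out lower numbers stand for stronger inhibition and higher numbers for weaker inhibition), compound 2 gives > 80000 nM, which is a limit of the assay and not a number. Compound 3 `CCOC(=O)CC1C(C(=O)OCC)=C(N)Oc2ccc(-c3cncnc3)cc21` differs from it by one change, pyrimidin-5-yl in place of thiophen-2-yl on an aromatic carbon. Among the measured compounds shown here, only one measured step bears on this change: an at least 7.4-fold higher number from compound 1 to compound 2 (0.87 log units; beyond the scatter), which lies beyond the scatter. For the measured compounds named here, it shows that the group on this aromatic carbon can matter, but no measured compound carries pyrimidin-5-yl, so it gives neither a size nor a direction for the new change. Going by the values given here, compound 1, at 10700 nM, is the only compound here with a number, and the new group does not resemble its 3,5-dimethoxyphenyl more closely in any counted way. The expected result in this assay is therefore no step beyond the scatter, written as an estimated a number no higher from compound 2 to compound 3 (the limit leaves the size open). For compound 3 the estimated value is 80000 nM, with an expected range from 30000 nM to 160000 nM.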

Compound 3, half-maximal inhibitory concentration: 37900 nM
The estimate for compound 3 lay 2.1-fold (0.32 log units) above the measured number; the measured number falls inside the stated range.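

In this assay, pyrimidin-5-yl on this aromatic carbon gives a measurable number where thiophen-2-yl does not, with an at least 2.1-fold lower number from compound 2 to compound 3 (0.32 log units; beyond the scatter). On these data alone, compound 2 carries a limit of the assay and not a number, and the size of this step stays open: the limit of > 80000 nM in this assay, at which 1 of the 3 values shown sits. Against 3,5-dimethoxyphenyl the same group gives a 3.5-fold higher number from compound 1 to compound 3 (0.55 log units; beyond the scatter), the first step at this position with a definite size, and compound 1 keeps the lowest number of the three.

The compounds shown leave open how an unsubstituted phenyl, a single methoxy group on that phenyl, or an amine or carboxylic acid on the aryl ring would read at this position. They also cannot tell why these groups differ, or whether the same order would hold on a change elsewhere in the shared core.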